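This account rests on a few compounds, and the source may have more. Where it says the series, first, only, none or still open, it means among the compounds named here.

Compound 1 `CC[C@@H](Nc1c(Nc2cccc(C(=O)N(C)C)c2O)c(=O)c1=O)c1sccc1C`: 123 nM
Compound 2 `CCc1coc([C@@H](CC)Nc2c(Nc3cccc(C(=O)N(C)C)c3O)c(=O)c2=O)c1`: 7 nM

In an assay on CHO cells for displacement of a labelled ligand from C-X-C chemokine receptor type 1 (Homo sapiens) (a higher number here means a weaker inhibitor, a lower number a stronger inhibitor), compound 2 gives the lowest number of the two measured compounds; compound 1 gives a higher number, and the step of an 18-fold lower number from compound 1 to compound 2 (1.24 log units; beyond the scatter) is large and beyond the scatter. Compound 3 `CCC(CC)c1coc([C@@H](CC)Nc2c(Nc3cccc(C(=O)N(C)C)c3O)c(=O)c2=O)c1` has not been measured. It differs from compound 2 by pentan-3-yl in place of ethyl on an aromatic carbon. Going by the values given here, the only measured step, an 18-fold lower number from compound 1 to compound 2 (1.24 log units; beyond the scatter), exchanged the ring itself rather than a group on it, so it does not bear directly on this change, and no step of this kind has been measured at all. Without such a comparison the plainest expectation is a change within or near the scatter, in no settled direction. Compound 3 is therefore estimated at 7 nM, with a range from 2.5 nM to 20 nM. The expected step is no change at the digits printed from compound 2 to compound 3 (within the scatter).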

Compound 3, inhibition constant: 30 nM
Beside the measured number, compound 3's estimate is 4.3-fold (0.63 log units) below it; the whole stated range lies below it.
By their numbers in this assay, from the lowest: compound 2; then compound 3; then compound 1.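

In this assay, the aromatic carbon two ring bonds from the ring oxygen proves sensitive to the group it carries: pentan-3-yl in place of ethyl gives a 4.3-fold higher number from compound 2 to compound 3 (0.63 log units; beyond the scatter). Going from 2 to 5 heavy atoms here therefore gives up part of the earlier gain, but not all of it, as 4-(pentan-3-yl)furan-2-yl in place of 3-methylthiophen-2-yl still gives a 4.1-fold lower number from compound 1 to compound 3 (0.61 log units; beyond the scatter). Nothing available here explains why the larger group gives the higher number.

With only ethyl and pentan-3-yl shown at this carbon, the two compounds define no trend with group size. Going by these compounds, how a methyl, a cyclopropyl or a chain ending in an amine would behave at this carbon remains open.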